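The compounds below may be only part of what the source reports. "The series", "measured", "known", "first", "only" and "open" are said of these compounds alone.

Measured so far:
- compound 1 `COc1cc(-c2ncnn2-c2ccc(Cl)cc2Cl)cc(OC)c1OC`: > 10000 nM
- compound 2 `COc1cccc(-c2ncnn2-c2cc(OC)c(OC)c(OC)c2)c1`: > 10000 nM
- compound 3 `COc1cc(-n2ncnc2-c2ccc(Cl)c(Cl)c2)cc(OC)c1OC`: > 10000 nM

All three were tested in a functional assay on K562 cells (Homo sapiens) for antiproliferative activity, read by MTT assay, with a stated time of 72 h; a lower number here means a stronger inhibitor, a higher number a weaker inhibitor. In this assay compound 1 gives > 10000 nM, which is a limit and not a number. The other two compounds offer no number either, and the picture is the same for the whole set: the limit of > 10000 nM in this assay, at which 3 of the 3 values shown sit.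

Compound 4 `COc1cc(-c2ncnn2-c2ccccc2)cc(OC)c1OC` changes compound 1 in one place: phenyl in place of 2,4-dichlorophenyl on an aromatic nitrogen. Phenyl replaces 2,4-dichlorophenyl on an aromatic nitrogen.

For the measured compounds named here, only one measured step exists, and it concerns a different change: a step that the two limits leave unreadable from compound 2 to compound 3. Going by the values given here, it therefore provides no size to carry over, and no measured step shows what removing the two chlorines does. With no readable step, neither direction can be expected, and no change beyond the scatter can be predicted. The most likely outcome is that compound 4 also reaches the limit in this assay.

The expected step, given here only as an estimate, is a number no higher from compound 1 to compound 4 (the limit leaves the size open). The estimate for compound 4 is 10000 nM, with an expected range from 3000 nM to 30000 nM.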

Compound 4, half-maximal inhibitory concentration: > 10000 nM
Compound 4 gave a limit, no number; the forecaster's own chance of this, stated with the estimate: 85%; the middle value lies on the limit itself.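

In this assay compound 4 gives > 10000 nM, which is a limit and not a number. Compound 1 also stands at a limit, so no step can be read between compound 1 and compound 4. The compounds shown leave open which change, if any, would yield a measurable value, since the whole set stays at one ceiling: the limit of > 10000 nM in this assay, at which 4 of the 4 values shown sit.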